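This account rests on a few compounds, and the source may have more. Where it says the series, first, only, none or still open, it means among the compounds named here.

Of the compounds shown here, three on a shared core have been read in an ADME assay on microsomes from liver (Canis lupus familiaris) for metabolic stability (on this read-out lower numbers stand for a shorter-lived compound and higher numbers for a longer-lived compound), and none of them yields a number. Compound 1 `Clc1ccc(-c2nc(NCCNc3ccccn3)ncc2-c2ncc[nH]2)c(Cl)c1` gives > 0.5 h as a limit of the assay. Compound 2 `Nc1nc(NCCNc2ncc(-c3ncc[nH]3)c(-c3ccc(Cl)cc3)n2)ccc1[N+](=O)[O-]` gives > 0.5 h as a limit too. Compound 3 `Nc1nc(NCCNc2ncc(-c3ncc[nH]3)c(-c3ccccc3Br)n2)ccc1[N+](=O)[O-]` gives > 0.5 h and this is likewise only a limit. Compound 3 thus stands at the limit of > 0.5 h in this assay, at which 3 of the 3 values shown sit, and has no number of its own. Compound 4 `Nc1nc(NCCNc2ncc(-c3ncc[nH]3)c(-c3ccc(Cl)cc3F)n2)ccc1[N+](=O)[O-]` differs from compound 3 by a single exchange, 4-chloro-2-fluorophenyl in place of 2-bromophenyl on an aromatic carbon and the rest of the structure stays the same. Going by the values given here, the one measured step that bears on this is a step that the two limits leave unreadable from compound 2 to compound 3 and it exchanges a group at the same place, yet it offers no size to carry over. No step beyond the scatter is therefore expected in this assay and no direction can be given. The estimate amounts to a step that the limit leaves unreadable from compound 3 to compound 4 as the expected step. Compound 4 is expected at 0.8 h with a range of 0.4 h to 1.6 h and will probably be reported as a limit again.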

Compound 4, half-life: > 0.5 h
Compound 4: a limit, no number; the forecaster's own chance of this, stated with the estimate: 80%; the middle value does not contradict the limit.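

In this assay, going by these compounds alone, compound 4 gives > 0.5 h as a limit, so no step from compound 2 or compound 3 to compound 4 can be read. All the compounds stay at one mark: the limit of > 0.5 h in this assay, at which 4 of the 4 values shown sit. The compounds shown leave open what half-life any of them actually has in this assay and whether any of these exchanges alters it.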